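Swapping an ethyl ester for methyl on a chloro-bearing chalcone

A few compounds are considered here, and "the series" means these few. Any claim that something is new, unique, unknown or untested is made for them only; others in the source may bear on it.

This series consists of four compounds sharing one core. Compound 1 `CCC(C)c1cc(/C=C/C(=O)c2ccccc2)cc2cc(C(=O)OC)c(=O)oc12` carries a methyl ester and a plain phenyl ketone; in a functional assay on MCF7 cells (Homo sapiens) for cytotoxicity, read by sulforhodamine B assay, with a stated time of 48 h (a higher number here means a weaker inhibitor, a lower number a stronger inhibitor), compound 1 gives 11400 nM. Compound 2 `CCOC(=O)c1cc2cc(/C=C/C(=O)c3ccccc3)cc(C(C)CC)c2oc1=O` differs from it by hydrogen in place of methyl on a saturated chain carbon bound to an oxygen next to a carbonyl group in the other direction, and in this assay compound 2 gives 88100 nM. Compound 3 `CCOC(=O)c1cc2cc(/C=C/C(=O)c3ccc(Cl)cc3)cc(C(C)CC)c2oc1=O` differs from compound 2 by chloro in place of hydrogen on an aromatic carbon, and in this assay compound 3 gives 11100 nM. Each change from compound 2 was of similar size: a 7.7-fold lower number from compound 2 to compound 1 (0.89 log units; beyond the scatter), and a 7.9-fold lower number from compound 2 to compound 3 (0.90 log units; beyond the scatter). Compound 4 `CCC(C)c1cc(/C=C/C(=O)c2ccc(Cl)cc2)cc2cc(C(=O)OC)c(=O)oc12` has not yet been measured; it differs from compound 3 by hydrogen in place of methyl on a saturated chain carbon bound to an oxygen next to a carbonyl group, the same change as between compound 2 and compound 1, made here on the core that already bears the chloro group. If that change repeats, compound 4 is expected to show a step of a 3.7-fold lower number from compound 3 to compound 4 (0.57 log units; beyond the scatter), close to the earlier one but not assumed to carry over in full since it rests on a single pair. Compound 4 is therefore estimated at 3000 nM, with a range from 900 nM to 12000 nM.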

Compound 4, half-maximal inhibitory concentration: 10800 nM
The estimate for compound 4 lay 3.6-fold (0.56 log units) below the measured number; the measured number falls inside the stated range.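

In this assay, the change from ethoxycarbonyl to methoxycarbonyl did not carry over in size to the core bearing the chloro group, where it gave a 1.0-fold lower number from compound 3 to compound 4 (0.01 log units; within the scatter): the same change on two cores in this assay, a 7.7-fold lower number (0.89 log units; beyond the scatter) from compound 2 to compound 1 and a 1.0-fold lower number (0.01 log units; within the scatter) from compound 3 to compound 4, 7.5-fold (0.88 log units) apart, beyond the scatter of two such steps. Chloro in place of hydrogen on an aromatic carbon behaved in the same way, giving a 1.1-fold lower number from compound 1 to compound 4 (0.02 log units; within the scatter) on the core with the methoxycarbonyl group, a step unlike the one it gave on the core with the ethoxycarbonyl group: the same change on two cores in this assay, a 7.9-fold lower number (0.90 log units; beyond the scatter) from compound 2 to compound 3 and a 1.1-fold lower number (0.02 log units; within the scatter) from compound 1 to compound 4, 7.5-fold (0.88 log units) apart, beyond the scatter of two such steps. Among these four compounds, neither change can therefore be treated as a fixed step that transfers from one core to the other, but this rests on a single set of four compounds and does not show why the steps differ or how either change would behave on any other core.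

The compounds shown leave open how a longer chain or a carboxylic acid would read in place of the ester. They also leave open whether an amine or a bromo group in place of the chloro group would give the same non-additive result.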